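Fluoro for Methyl: Estimating Compound 3

A few compounds are considered here, and "the series" means these few. Any claim that something is new, unique, unknown or untested is made for them only; others in the source may bear on it.

Two compounds have been measured in an assay on CHO-K1 cells for displacement of a labelled ligand from 5-hydroxytryptamine receptor 7 (Homo sapiens), read by scintillation counting; a higher number here means a weaker inhibitor, a lower number a stronger inhibitor:
- Compound 1, `COc1ccccc1N1CCN(CCCC(=O)NCc2ccccc2-c2ccccc2)CC1`, gives 64.5 nM.
- Compound 2, `COc1ccccc1N1CCN(CCCCC(=O)NCc2ccccc2-c2ccccc2C)CC1`, gives 26.1 nM.

Compound 2 holds the lower of the two numbers, and the nearest neighbour, compound 1, lies higher by more than the usual scatter, so on these two values compound 2 is the stronger inhibitor. Among the measured compounds shown here, the two compounds differ in more than one place, so no single step between them can be read off.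

Compound 3, `COc1ccccc1N1CCN(CCCCC(=O)NCc2ccccc2-c2ccccc2F)CC1`, differs from compound 2 by fluoro in place of methyl on an aromatic carbon. For the measured compounds named here, no measured pair changes this place, so there is no direct precedent in this assay. A small step, not beyond the scatter and in either direction, is what is expected for a 1.3-fold higher number from compound 2 to compound 3 (0.13 log units; within the scatter). Compound 3 is therefore estimated at 35 nM, with a likely range from 12 nM to 100 nM.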

Compound 3, inhibition constant: 36.5 nM
Estimate against measurement, compound 3: 1.0-fold (0.02 log units) below; the measured number falls inside the stated range.
By their numbers in this assay, from the lowest: compounds 2, 3 and 1 (each within the scatter of the next, the first and the last beyond it).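

In this assay, among the compounds shown here, the change from 2-methylphenyl to 2-fluorophenyl is a 1.4-fold higher number from compound 2 to compound 3 (0.15 log units; within the scatter), the first step in this set that can be read at a single place. On this aromatic carbon, ortho to a large group, the methyl and fluoro groups cannot be told apart by this read-out, although this rests on one pair alone. Nothing at hand explains why the two groups read alike.

From the compounds shown here alone, what a hydrogen, a chloro, a methoxy or a trifluoromethyl group would give at this place remains open. Compound 1 differs from compound 2 in both the chain and the ring methyl, so the contribution of the chain length to the binding of these compounds also stays unresolved.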